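The source may hold more compounds than are shown below. What is called first, only, known or untested is meant among the compounds shown, and "the series" means these compounds.

Measured compounds in hand:
- compound 1, `CC(C)(C)OC(=O)N1CCN(c2ncc(OCc3ccc(S(C)(=O)=O)cc3)nn2)CC1`: 161 nM in an in vitro functional assay on HEK293S cells for agonist activity at Glucose-dependent insulinotropic receptor (Homo sapiens), read by HTRF and cAMP accumulation, with a stated time of 45 min; a higher number here means that more compound is needed for the effect, a lower number that less compound is needed
- compound 2, `C[C@@H]1CN(C(=O)OC(C)(C)C)CCN1c1ncc(OCc2ccc(S(C)(=O)=O)cc2C#N)cn1`: 16 nM in this assay
- compound 3, `Cc1cc(COc2cnc(N3CCN(C(=O)OC(C)(C)C)CC3)nc2)ccn1`: > 1930 nM in this assay

The reading for compound 3 is a limit of the assay and not a number; it sits at the limit of > 1930 nM in this assay, at which 1 of the 3 values shown sits. For the measured compounds named here, compound 1 and compound 2 both give numbers, and compound 2 comes in lower than compound 1, but no step between any two measured compounds is computed here, so only the two values themselves are noted.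

Compound 4, `CC(C)(C)OC(=O)N1CCN(c2ncc(OCc3ccncc3F)cn2)CC1`, has not yet been measured in this assay. It differs from compound 3 by 3-fluoropyridin-4-yl in place of 2-methylpyridin-4-yl on a saturated chain carbon bound to an oxygen on an aromatic ring. With compound 3 only at a limit, no measured step sizes the effect of exchanging one pyridinyl for another; the expectation is a change of no more than the usual scatter in this assay, in either direction, and a fair chance that compound 4 again reports only a limit. The value expected for compound 4 is 3000 nM, with a range from 800 nM to 10000 nM. The step from compound 3 to compound 4 that this estimate implies is a step that the limit leaves unreadable from compound 3 to compound 4, and it is an expectation only.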

Compound 4, half-maximal effective concentration in the Glucose-dependent insulinotropic receptor assay: 63 nM
For compound 4 the middle estimate is 48-fold (1.68 log units) above the measured one, outside the stated range (below it).
By their numbers in the Glucose-dependent insulinotropic receptor assay, from the lowest: compound 2; then compound 4; then compound 1. At a limit, above all of these: compound 3.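

For the compounds shown here, in the Glucose-dependent insulinotropic receptor assay, 3-fluoropyridin-4-yl in place of 2-methylpyridin-4-yl on a saturated chain carbon bound to an oxygen on an aromatic ring gives an at least 30-fold lower number from compound 3 to compound 4 (1.48 log units; beyond the scatter), the first step that can be read, and it shows that this position responds strongly to the choice of substituted pyridinyl. The reading for compound 3, > 1930 nM, is a limit of the assay, so the step has a minimum size and no exact one. The same exchange also carries a measured cost, as in a physicochemical assay for solubility, in phosphate buffer, at pH 7.4 (a higher number here means a more soluble compound, a lower number a less soluble compound), the solubility falls beyond the scatter: the measured solubility of compound 3, 66000 nM, and of compound 4, 5100 nM, a 13-fold lower number (1.11 log units; beyond the scatter) In the physicochemical assay compound 3 gives 66000 nM and compound 4 gives 5100 nM.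

Still open, as far as these compounds go, is how much of the change in the Glucose-dependent insulinotropic receptor assay goes with the arrival of the fluorine and how much with the departure of the methyl, a question that unsubstituted pyridin-4-yl at this position would help to separate. Also open, from the compounds shown here alone, is whether an amine or a carboxylic acid on the pyridinyl would keep the low number of compound 4 in the Glucose-dependent insulinotropic receptor assay while giving back the solubility seen for compound 3 in the physicochemical assay.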